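Fluoro for chloro on the quaternary ammonium series, a forecast

The compounds below may be only part of what the source reports. "The series", "measured", "known", "first", "only" and "open" are said of these compounds alone.

Compound 3 `CN(C)c1ccc2c(=O)c(C(=O)Nc3cc(F)cc(F)c3)cn(-c3ccc(OCCCCCCC[N+]4(C)CCCC4)cc3Cl)c2n1` is reported in an assay on LX2 cells for inhibition of COL1A1 promoter (Homo sapiens), read by a luciferase reporter, with a stated time of 24 h, tested at 50 uM (on this read-out higher numbers stand for a stronger effect at the one concentration tested and lower numbers for a weaker effect), as "not active" (no number reported), with no single number behind it. Compound 2 `Cc1cc(OCCCCCCC[N+]2(C)CCCC2)ccc1-n1cc(C(=O)Nc2cc(F)cc(F)c2)c(=O)c2ccc(N(C)C)nc21` likewise gives "not active" (no number reported) in this assay, also without a number. Compound 1 `CN(C)c1ccc2c(=O)c(C(=O)Nc3cc(F)cc(F)c3)cn(-c3ccc(OCCCCCCC[N+]45CCN(CC4)CC5)cc3F)c2n1`, which carries a different charged group and a fluoro on the aromatic ring, gives 42.4% in this assay. Compound 4 `CN(C)c1ccc2c(=O)c(C(=O)Nc3cc(F)cc(F)c3)cn(-c3ccc(OCCCCCCC[N+]4(C)CCCC4)cc3F)c2n1` is not yet measured. It differs from compound 3 by fluoro in place of chloro on an aromatic carbon. Going by the values given here, no measured pair isolates this change, so its size in this assay is unknown; a shift within the scatter or at most a modest rise is expected. Given that compound 3 shows no number while compound 1 reaches 42.4%, compound 4 is expected near 15% in this assay, within 0% to 40%.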

Compound 4, a percentage reported as inhibition, at one concentration (the size of the read-out at that concentration, not a potency): "not active" (no number reported)
Compound 4: no number reported, and the estimate cannot be compared.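

In this assay, going by these compounds alone, compound 3 and compound 4 both stand without a number, and no step between them can be read. Left open is whether fluoro versus chloro at this place changes the read-out in a compound that gives a number. Nothing shown offers an explanation for these results.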